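Serine side chain in place of glutamate in the amide series

A few compounds are considered here, and "the series" means these few. Any claim that something is new, unique, unknown or untested is made for them only; others in the source may bear on it.

Of the compounds shown here, three of one shared core have been measured in a functional assay on the whole organism (Tail, strain ICR) with Mus musculus as the target, in the tail flick test, with a stated time of 60 min, at a dose of 25 umol/kg by the oral route; a lower number here means a weaker effect, a higher number a stronger effect of the compound at the dose given. Compound 1 `O=C(O)[C@@H]1CCCN1C(=O)CN(c1nc(Cl)nc2[nH]cnc12)C1CC1` gives 34.9% in this assay. Compound 2 `C[C@H](NC(=O)CN(c1nc(Cl)nc2[nH]cnc12)C1CC1)C(=O)O` gives 44.6%, the step of a number 9.7 percentage points higher from compound 1 to compound 2 (within the scatter) staying within the scatter. Compound 3 `O=C(O)CC[C@H](NC(=O)CN(c1nc(Cl)nc2[nH]cnc12)C1CC1)C(=O)O` gives 33.3%, which is the lowest of the three numbers: compound 1 is nearest, within the scatter, and compound 2 furthest, beyond it, the step being a number 11.3 percentage points lower from compound 2 to compound 3 (beyond the scatter).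

Compound 4 `O=C(CN(c1nc(Cl)nc2[nH]cnc12)C1CC1)N[C@@H](CO)C(=O)O` differs from compound 3 by hydroxy in place of carboxymethyl on a saturated chain carbon, two bonds along the chain from an amide-type nitrogen and a carbonyl carbon. Going by the values given here, the only measured step that bears on this position is the one from compound 2 to compound 3, where carboxymethyl entered in place of hydrogen and the number fell modestly. Among the compounds with values here, removing the carboxymethyl again, now with hydroxy in its place, is expected to undo part of that fall; a modest rise is therefore expected, a number 8.7 percentage points higher from compound 3 to compound 4 (within the scatter), though the hydroxy itself has no measured precedent. Compound 4 is expected to give about 42% in this assay, with a range from 30% to 54%.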

Compound 4, a percentage reported as activity, at one dose (the size of the read-out at that dose, not a potency): 39.8%
Compound 4: middle estimate off by 2.2 percentage points, on the high side; the range from low to high includes it.
By their numbers in this assay, from the lowest: compounds 3, 1, 4 and 2 (each within the scatter of the next, the first and the last beyond it).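

In this assay hydroxy on this saturated chain carbon is not separated from carboxymethyl (a number 6.5 percentage points higher from compound 3 to compound 4 (within the scatter)) or from hydrogen (a number 4.8 percentage points lower from compound 2 to compound 4 (within the scatter)), so the step from compound 2 to compound 3 (a number 11.3 percentage points lower from compound 2 to compound 3 (beyond the scatter)) remains the only one beyond the scatter at this position. Compound 4 is likewise not separated from the core of compound 1 with its 2-carboxypyrrolidin-1-yl group (a number 4.9 percentage points higher from compound 1 to compound 4 (within the scatter)). Nothing shown gives a reason for these steps.

On these data alone, whether an amine or a longer chain ending in hydroxy on this saturated chain carbon would give a step beyond the scatter remains open. A carboxylic acid placed directly on this carbon is also an open case, and a read-out at a single dose leaves potency open for all four compounds.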